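Fluoro for hydrogen in a carbinol cytotoxicity series

A few compounds are considered here, and "the series" means these few. Any claim that something is new, unique, unknown or untested is made for them only; others in the source may bear on it.

Measured so far:
compound 1 `CC(C)Oc1ccc(C(O)(c2ccc(Cl)cc2)c2cccnc2)cc1`: 56600 nM
compound 2 `CC(C)Oc1ccc(C(O)(c2ccc(Cl)cc2)c2cccnc2)c(F)c1`: 58200 nM
compound 3 `OC(c1ccc(Cl)cc1)(c1cccnc1)c1cccs1`: 67700 nM

In an ADME assay on L6 cells (Rattus norvegicus) for cytotoxicity, read by resazurin assay, with a stated time of 72 h (a higher number here means a weaker inhibitor, a lower number a stronger inhibitor), compound 1 gives 56600 nM and compound 2 gives 58200 nM; the change fluoro in place of hydrogen on an aromatic carbon made a 1.0-fold higher number from compound 1 to compound 2 (0.01 log units; within the scatter). Compound 3 gives 67700 nM in this assay; the difference between its core and that of compound 1 is not broken down here, and its number lies within the scatter of both compound 1 and compound 2. Compound 4 `OC(c1cccnc1)(c1cccs1)c1ccc(Cl)cc1F` is not yet measured in this assay. It differs from compound 3 by fluoro in place of hydrogen on an aromatic carbon, the same kind of change as from compound 1 to compound 2, though here the place is meta to a chloro group rather than meta to an isopropoxy group. Because a 1.0-fold higher number from compound 1 to compound 2 (0.01 log units; within the scatter) lay within the scatter, the expected step is a 1.0-fold higher number from compound 3 to compound 4 (0.01 log units; within the scatter). Compound 4 is therefore estimated at 69000 nM, between 40000 nM and 120000 nM.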

Compound 4, half-maximal inhibitory concentration: > 100000 nM
Compound 4 gave a limit, no number (the forecaster's own chance of this, stated with the estimate: 15%); middle value at least 1.4-fold (0.16 log units) from the limit.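

In this assay, fluoro in place of hydrogen on an aromatic carbon gives an at least 1.4-fold higher number from compound 3 to compound 4 (0.16 log units; that floor lies within the scatter). Compound 4 reads > 100000 nM, which is a limit of the assay and not a number, so this step is known only as a floor. The floor shows no change beyond the scatter on the second core, but it does not show that the change carries over unaltered, nor that it behaves differently there: the same change on two cores in this assay, a 1.0-fold higher number (0.01 log units; within the scatter) from compound 1 to compound 2 and an at least 1.4-fold higher number (0.16 log units; that floor lies within the scatter) from compound 3 to compound 4; the limit leaves it open whether they differ

Going by these compounds, the actual value of compound 4 remains open. Also open, on these data alone, is how an amine or a carboxylic acid on the same aromatic carbon, in place of the fluoro, would read in this assay on either core.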